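The compounds below may be only part of what the source reports. "The series", "measured", "known", "first", "only" and "open" are said of these compounds alone.

Of the compounds shown here, three have so far been measured in a functional assay on MOLT-4 cells (Homo sapiens) for cytotoxicity, with a stated time of 72 h; on this read-out higher numbers stand for weaker inhibition and lower numbers for stronger inhibition. Compound 1 `CN(C)c1ccc(/C=C2\CCC/C(=C\c3ccccc3[N+](=O)[O-])C2=O)cc1` gives 122000 nM. Compound 2 `O=C1/C(=C/c2ccc(Cl)cc2)CCC/C1=C\c1ccccc1[N+](=O)[O-]` gives 3860 nM, and compound 3 `O=C1/C(=C/c2ccc(Cl)cc2)CCC/C1=C\c1cccc([N+](=O)[O-])c1` gives 2020 nM. How the cores of compound 2 and compound 3 differ is not broken down here. Within the pair that shares a core, the change dimethylamino in place of chloro on an aromatic carbon produced a 32-fold higher number from compound 2 to compound 1 (1.50 log units; beyond the scatter). Compound 4 `CN(C)c1ccc(/C=C2\CCC/C(=C\c3cccc([N+](=O)[O-])c3)C2=O)cc1` has not yet been measured; it arises from compound 3 by the same change, (dimethylamino in place of chloro on an aromatic carbon), made at the same place. Because the earlier step of a 32-fold higher number from compound 2 to compound 1 (1.50 log units; beyond the scatter) was large, a step of comparable size is expected here, namely a 30-fold higher number from compound 3 to compound 4 (1.47 log units; beyond the scatter). Compound 4 is therefore estimated to give 60000 nM, with a plausible range from 15000 nM to 200000 nM.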

Compound 4, half-maximal inhibitory concentration: 10900 nM
Compound 4: the middle estimate sits 5.5-fold (0.74 log units) above what was measured; measured number below the stated range.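

In this assay the swap of chloro for dimethylamino gives a higher number on both cores, but the size of the step does not carry over from one core to the other: the same change on two cores in this assay, a 32-fold higher number (1.50 log units; beyond the scatter) from compound 2 to compound 1 and a 5.4-fold higher number (0.73 log units; beyond the scatter) from compound 3 to compound 4, 5.9-fold (0.77 log units) apart, beyond the scatter of two such steps. The new step is a 5.4-fold higher number from compound 3 to compound 4 (0.73 log units; beyond the scatter) and, with dimethylamino kept, 3-nitrophenyl in place of 2-nitrophenyl gives an 11-fold lower number from compound 1 to compound 4 (1.05 log units; beyond the scatter) on the way from one core to the other. These two pairs show that the step depends on the core, but they give no reason for the gap and no rule for predicting the step on a further core.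

Still open, on these data alone, is whether other groups in place of chloro, such as methoxy, a primary amine or a carboxylic acid, would also give steps that differ between the cores. Also open, as far as these compounds go, is how a nitrile in place of the nitro group would change the numbers.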